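Swapping the aryl on the sulfonamide of an HSP60/HSP10 series

The compounds below may be only part of what the source reports. "The series", "measured", "known", "first", "only" and "open" are said of these compounds alone.

Measured so far in an assay on cells for inhibition of HSP60/HSP10 (Homo sapiens), with a stated time of 60 min; a higher number here means a weaker inhibitor, a lower number a stronger inhibitor:
- compound 1 `O=S(=O)(Nc1ccc(-c2nc3ccccc3o2)cc1)c1cccc(F)c1` gives 71000 nM
- compound 2 `CS(=O)(=O)Nc1ccc(-c2nc3ccccc3o2)cc1` gives > 100000 nM, which is a limit of the assay
- compound 3 `COc1ccc(S(=O)(=O)Nc2ccc(-c3nc4ccccc4o3)cc2)cc1` gives > 100000 nM, which is a limit of the assay

All three share one core and differ only in the group on the sulfonyl sulfur. From the compounds shown here alone, compound 3, carrying a 4-methoxyphenyl there, sits at the limit described by the limit of > 100000 nM in this assay, at which 2 of the 3 values shown sit, so its true number is unknown beyond that. The step of an at least 1.4-fold higher number from compound 1 to compound 3 (0.14 log units; that floor lies within the scatter) and the step of an at least 1.4-fold higher number from compound 1 to compound 2 (0.14 log units; that floor lies within the scatter) are both only floors, and the step that the two limits leave unreadable from compound 2 to compound 3 cannot be read at all.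

Compound 4 `Cc1cccc(S(=O)(=O)Nc2ccc(-c3nc4ccccc4o3)cc2)c1` differs from compound 3 by 3-methylphenyl in place of 4-methoxyphenyl on a sulfonyl sulfur. Its closest measured relative is compound 1, whose 3-fluorophenyl also carries a single substituent on the phenyl ring, and which gives a number rather than a limit. The change an at least 1.1-fold lower number from compound 3 to compound 4 (0.07 log units; that floor lies within the scatter) is therefore expected to be small, if it is seen at all. For compound 4 the value in this assay is estimated at 85000 nM, within a range from 35000 nM to 200000 nM, with a fair chance that only a limit is reported.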

Compound 4, half-maximal inhibitory concentration: > 100000 nM
Compound 4: only a limit was reported; the forecaster's own chance of this, stated with the estimate: 45%; middle value at least 1.1-fold (0.07 log units) from the limit.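

Placing methyl in place of fluoro on an aromatic carbon gives an at least 1.4-fold higher number from compound 1 to compound 4 (0.14 log units; that floor lies within the scatter), so even this small change at a single substituent on the phenyl ring yields only a floor and no measurable size. For the compounds shown here, with 3-methylphenyl joining methyl and 4-methoxyphenyl at the limit, compound 1 with its 3-fluorophenyl remains the only compound here with a number, though its steps to the other compounds are floors within the scatter and set no order among them. The steps to compound 4 from compound 2 and from compound 3 cannot be read, because each has a limit at both ends: the limit of > 100000 nM in this assay, at which 3 of the 4 values shown sit.

From the compounds shown here alone, how far compound 1 truly stands from the other three remains unknown. Also open, going by these compounds, is whether 3-chlorophenyl, or a phenyl carrying a carboxylic acid or an amine, on the sulfonyl sulfur would give a number rather than a limit.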